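Pyrrole to methylimidazole on the benzylic carbon

The compounds below may be only part of what the source reports. "The series", "measured", "known", "first", "only" and "open" are said of these compounds alone.

Measured compounds:
compound 1 `NC(=O)C1(c2cccc(Sc3ccc(-n4cnnc4)cc3)c2)CCOCC1` — "not determined" (no result reported) in a functional assay for inhibition of Polyunsaturated fatty acid 5-lipoxygenase (Mus musculus); a lower number here means that less compound is needed, a higher number that more compound is needed for the effect
compound 2 `Cc1cc(C)n(-c2ccc(Sc3cccc(C4(C(N)=O)CCOCC4)c3)cc2)n1` — "not determined" (no result reported) in this assay
compound 3 `NC(=O)C1(c2cccc(Sc3ccc(Cn4cccc4)cc3)c2)CCOCC1` — 3 mg/kg in this assay

Three compounds of this series share a core, but only compound 3 carries a number in this assay. Compound 1 and compound 2 were not characterised there, so nothing can be said about how either compares with compound 3. Going by the values given here, compound 3 therefore stands alone: its value in this assay is the sole reference point, and no step between two measured compounds is available to show how a change on the outer ring shifts the read-out.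

Compound 4 `Cc1nccn1Cc1ccc(Sc2cccc(C3(C(N)=O)CCOCC3)c2)cc1` is the next compound to be tested in this assay. It differs from compound 3 in one place: 2-methyl-1H-imidazol-1-yl in place of 1H-pyrrol-1-yl on a saturated chain carbon bound to an aromatic carbon. The change keeps the methylene link and the rest of the molecule unchanged.

Among the compounds with values here, with no measured pair to lean on, the expectation for compound 4 rests on compound 3 alone and on the modest size of the change; the step from compound 3 to compound 4 is expected to be no change at the digits printed from compound 3 to compound 4 (within the scatter), which is not beyond the usual scatter. Compound 4 is therefore estimated at 3 mg/kg in this assay, with a range from 1 mg/kg to 10 mg/kg.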

Compound 4, dose for half-maximal effect: > 20 mg/kg
Compound 4 gave a limit, no number; the forecaster's own chance of this, stated with the estimate: 10%; middle value at least 6.6-fold (0.82 log units) from the limit.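

In this assay, going by these compounds alone, placing 2-methyl-1H-imidazol-1-yl in place of 1H-pyrrol-1-yl on a saturated chain carbon bound to an aromatic carbon gives an at least 6.6-fold higher number from compound 3 to compound 4 (0.82 log units; beyond the scatter), and this is the only step between two measured compounds. Going by these compounds, compound 4 gives a limit of the assay rather than a number, so the full size of the step stays unknown: the limit of > 20 mg/kg in this assay, at which 1 of the 4 values shown sits. Even so, the result shows what compound 1 and compound 2, with no result reported, could not: the read-out at this place responds to the exchange of one five-membered aromatic ring for another, even with the methylene link and the rest of the molecule kept the same.

The step combines an added ring nitrogen with an added methyl, so the compounds shown cannot say which of the two accounts for it; the unsubstituted 1H-imidazol-1-yl group or the 2-methyl-1H-pyrrol-1-yl group would separate them. They also leave open whether a dimethylamino group or a longer chain on the same carbon would retain the dose of compound 3, 3 mg/kg.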